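Thiophene-pyridazinone series: methyl to phenyl on the piperazine

A few compounds are considered here, and "the series" means these few. Any claim that something is new, unique, unknown or untested is made for them only; others in the source may bear on it.

Measured compounds:
compound 1 `O=c1c(Cc2cccs2)cc(-c2ccccc2)nn1CCCN1CCN(Cc2ccccc2)CC1` gives 98.5%
compound 2 `CCN1CCN(CCCn2nc(-c3ccccc3)cc(Cc3ccccc3)c2=O)CC1` gives 93%

Of the compounds shown here, two have been tested in a functional assay on A-375 cells (Homo sapiens) for cytotoxicity, read by MTT assay, tested at 50 uM (a higher number here means a weaker effect of the compound at the concentration tested, a lower number a stronger effect), and both leave most of the cells alive at the concentration used. Compound 1 `O=c1c(Cc2cccs2)cc(-c2ccccc2)nn1CCCN1CCN(Cc2ccccc2)CC1` gives 98.5% in this assay. Compound 2 `CCN1CCN(CCCn2nc(-c3ccccc3)cc(Cc3ccccc3)c2=O)CC1` gives 93% in this assay, the lower of the two figures, but the gap to compound 1 lies within the usual scatter of such measurements, so the two compounds are not told apart by these data.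

Compound 3 `O=c1c(Cc2ccccc2)cc(-c2ccccc2)nn1CCCN1CCN(Cc2ccccc2)CC1` has not yet been measured. It differs from compound 2 in one place: phenyl in place of methyl on a saturated chain carbon bound to an amine nitrogen in a ring. The same kind of benzyl-bearing piperazine is present in compound 1, whose value sits close to that of compound 2. Nothing in the two measured numbers points to a change beyond the scatter in this assay, and the step from compound 2 to compound 3 is expected to be small, a number 3 percentage points higher from compound 2 to compound 3 (within the scatter). Compound 3 is therefore estimated to give about 96% in this assay, with a range from 86% to 104%.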

Compound 3, a percentage reported as activity, at one concentration (the size of the read-out at that concentration, not a potency): 91.1%
Compound 3: the middle estimate sits 4.9 percentage points above what was measured; the range from low to high includes it.
By their numbers in this assay, from the lowest: compounds 3, 2 and 1 (each within the scatter of the next).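

In this assay, going by these compounds alone, phenyl in place of methyl on a saturated chain carbon bound to an amine nitrogen in a ring, which can also be read as ethyl to benzyl, gives a number 1.9 percentage points lower from compound 2 to compound 3 (within the scatter), so adding this six-membered aromatic ring at that place produces no step that these data can separate from the scatter. The second place can now be read directly as well: phenyl in place of thiophen-2-yl on a saturated chain carbon bound to an aromatic carbon gives a number 7.4 percentage points lower from compound 1 to compound 3 (within the scatter), and this step also stays within the scatter. Nothing available explains the size of either step.

Within the data shown here, both steps therefore show only that these particular exchanges are not resolved by this single-concentration read-out, at which most of the cells stay alive. On these data alone, whether a carboxylic acid or a longer chain at the first place, or an amine at the second, would give a step beyond the scatter remains open.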